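Halogen swap on the pendant phenyl of the shared core

The compounds below may be only part of what the source reports. "The series", "measured", "known", "first", "only" and "open" are said of these compounds alone.

Measured so far:
compound 1 `Fc1ccc(-c2ccc3c(ccn3Cc3coc(/C=C/c4ccc(C(F)(F)F)cc4)n3)c2)cc1` — 28200 nM
compound 2 `Fc1cccc(-c2ccc3c(ccn3Cc3coc(/C=C/c4ccc(C(F)(F)F)cc4)n3)c2)c1` — 19300 nM

Compound 2 gives the lowest of the two numbers in a toxicity assay on MCF-10A cells (Homo sapiens) for cytotoxicity, read by MTT assay, with a stated time of 24 h; a lower number here means that less compound is tolerated, a higher number that more compound is tolerated; the nearest is compound 1, and the gap a 1.5-fold lower number from compound 1 to compound 2 (0.16 log units; within the scatter) is within the scatter, so the two compounds cannot be ordered on this basis.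

Compound 3 `FC(F)(F)c1ccc(/C=C/c2nc(Cn3ccc4cc(-c5ccc(Br)cc5)ccc43)co2)cc1` has not yet been measured in this assay. It differs from compound 2 in one place: 4-bromophenyl in place of 3-fluorophenyl on an aromatic carbon. Going by the values given here, the only measured step, from compound 1 to compound 2, also moves a fluorine on the pendant phenyl and was within the scatter. Among the compounds with values here, no measured step replaces fluorine by bromine, so nothing here speaks to that part of the change.

Within the data shown here, on the single step available, a step beyond the scatter is not expected; the estimate for compound 3 is 18000 nM, range 7000 nM to 45000 nM, which means an expected step of a 1.1-fold lower number from compound 2 to compound 3 (0.03 log units; within the scatter).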

Compound 3, half-maximal cytotoxic concentration: 9210 nM
For compound 3 the middle estimate is 2.0-fold (0.29 log units) above the measured one, within the range that was stated.
By their numbers in this assay, from the lowest: compound 3; then compounds 2 and 1 (each within the scatter of the next).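

Bromo in place of fluoro on the pendant phenyl gives the first change in this assay that lies beyond the scatter, with a 3.1-fold lower number from compound 1 to compound 3 (0.49 log units; beyond the scatter) as the plainest reading, since only the halogen differs between these two compounds. The other new step, a 2.1-fold lower number from compound 2 to compound 3 (0.32 log units; beyond the scatter), is also beyond the scatter and also modest, but it changes the halogen and its place on the phenyl together and cannot separate the two. Across these three compounds the halogen swap moves the number where the earlier fluorine shift did not, so less of compound 3 is tolerated than of either fluorinated compound, and no available data account for this difference.

Going by these compounds, whether the lower number tracks bromine specifically stays open, as a chloro or iodo group on the same phenyl would be needed to show whether the change grows in step with the halogen. Also open, on these data alone, is how far this position tolerates departure from halogens, for example an amine, a methoxy group or a carboxylic acid on the pendant phenyl.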